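Methyl ester of compound 1: expected inhibition on HepG2

The source may hold more compounds than are shown below. What is called first, only, known or untested is meant among the compounds shown, and "the series" means these compounds.

Measured so far:
compound 1 `O=C(/C=C/c1ccc(O)c(O)c1)OC[C@H]1O[C@@]2(C(=O)O)C[C@@H](OC(=O)/C=C/c3ccc(O)c(O)c3)[C@@H](OC(=O)/C=C/c3ccc(O)c(O)c3)[C@H]1O2` — 59500 nM
compound 2 `COC(=O)[C@]12C[C@@H](O)[C@@H](O)[C@H](O1)[C@@H](COC(=O)/C=C/c1ccc(O)c(O)c1)O2` — 86000 nM

In a functional assay on HepG2 cells (Homo sapiens) for inhibition, read by spectrophotometry, with stated times of 5 min and 1 h (on this read-out higher numbers stand for weaker inhibition and lower numbers for stronger inhibition), compound 1 gives 59500 nM. Of the two numbers in hand this is the lower one, but compound 2 gives 86000 nM in this assay, and the gap between the two falls within the scatter of repeated measurements, so no order can be read from them. Both compounds are weak inhibitors on this read-out.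

Compound 3 `COC(=O)[C@]12C[C@@H](OC(=O)/C=C/c3ccc(O)c(O)c3)[C@@H](OC(=O)/C=C/c3ccc(O)c(O)c3)[C@@H](O1)[C@@H](COC(=O)/C=C/c1ccc(O)c(O)c1)O2` has not yet been measured. It differs from compound 1 by methyl in place of hydrogen on an oxygen next to a carbonyl group. For the measured compounds named here, no pair of measured compounds isolates this change, so the step cannot be calibrated from the data; the only guidance is that compound 1 and compound 2, which differ in several places at once, sit close together in this assay.

Compound 3 is therefore expected to stay near compound 1, with the step from compound 1 to compound 3 in this assay not beyond the scatter, a 1.0-fold higher number from compound 1 to compound 3 (0.00 log units; within the scatter). The estimate for compound 3 in this assay is 60000 nM, with a range from 20000 nM to 180000 nM.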

Compound 3, half-maximal inhibitory concentration: 26000 nM
The estimate for compound 3 lay 2.3-fold (0.36 log units) above the measured number; the range from low to high includes it.
By their numbers in this assay, from the lowest: compound 3; then compounds 1 and 2 (each within the scatter of the next).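

For the compounds shown here, exchanging carboxy for methoxycarbonyl on the shared core gives a 2.3-fold lower number from compound 1 to compound 3 (0.36 log units; beyond the scatter) in this assay, which is the first step that isolates a single place. The earlier compounds shown here differed in several places at once and gave no order, whereas this modest step lies beyond the scatter and shows that the number responds to what sits on this oxygen next to a carbonyl group. A free carboxy group is therefore not required for inhibition on this read-out, and methyl in place of hydrogen strengthens it somewhat on this core. No measurement shown here offers an explanation for the shift.

The compounds shown leave open whether the shift is particular to methyl or would extend to a longer chain such as ethyl on the same oxygen, or to an amide or a primary alcohol at this position. They also leave open whether carboxy to methoxycarbonyl has the same effect on its own with fewer ester side chains on the core, since this step has been read only once.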